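Swapping cyclopentyl for cyclopentenyl: a cytotoxicity question

A few compounds are considered here, and "the series" means these few. Any claim that something is new, unique, unknown or untested is made for them only; others in the source may bear on it.

Results in an ADME assay on Huh-7 cells (Homo sapiens) for cytotoxicity, with a stated time of 72 h; a higher number here means that more compound is tolerated, a lower number that less compound is tolerated:

Compound 1 `CC(C)CCn1nc(-c2cccs2)c(O)c(C2=NS(=O)(=O)c3cc(S(C)(=O)=O)ccc3N2)c1=O`: "not determined" (no result reported).
Compound 2 `CC(C)CCn1nc(-c2ccccc2)c(O)c(C2=NS(=O)(=O)c3cc(NS(C)(=O)=O)ccc3N2)c1=O`: > 1000 nM, a limit.
Compound 3 `CC(C)CCn1nc(C2CCCC2)c(O)c(C2=NS(=O)(=O)c3cc(NS(C)(=O)=O)ccc3N2)c1=O`: > 1000 nM, a limit.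

Compound 3 has no exact number on this scale. Its result is only the limit > 1000 nM. The same is true of compound 2, and compound 1 offers no result for comparison.

Compound 4 `CC(C)CCn1nc(C2=CCCC2)c(O)c(C2=NS(=O)(=O)c3cc(NS(C)(=O)=O)ccc3N2)c1=O` keeps the shared core and changes one group: cyclopent-1-en-1-yl in place of cyclopentyl on an aromatic carbon. The ring size stays the same, and the new group adds one double bond outside aromatic rings.

Among the compounds with values here, only one measured step bears on this change: a step that the two limits leave unreadable from compound 2 to compound 3. Both of its ends are limits, so it gives no size to carry over. The remaining evidence is the limit of > 1000 nM in this assay, at which 2 of the 3 values shown sit.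

Starting from the limit of compound 3 at > 1000 nM, no step beyond the usual scatter is expected in this assay, and compound 4 will probably be reported only as a limit too. The expected change is a step that the limit leaves unreadable from compound 3 to compound 4, which is an estimate. For compound 4 the estimated value is 2000 nM, with an expected range from 1000 nM to 10000 nM.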

Compound 4, half-maximal cytotoxic concentration: > 1000 nM
Compound 4 was reported as a limit (the forecaster's own chance of this, stated with the estimate: 85%); the middle value lies beyond the limit too.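

Compound 4 gives > 1000 nM in this assay, which is a limit. Within the data shown here, compound 2 and compound 3 are reported only as limits too, so no step to compound 4 from either can be read. Whether phenyl, cyclopentyl and cyclopent-1-en-1-yl differ at all in this assay stays open, as the results stop at one value: the limit of > 1000 nM in this assay, at which 3 of the 4 values shown sit.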